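The source may report more compounds than this note shows. Statements on the series, on what has been measured and on what is new or still open speak of the compounds shown alone.

Three compounds were measured in a functional assay on NCI-H1975 cells (Homo sapiens) for inhibition, read by MTT assay, with a stated time of 72 h; on this read-out lower numbers stand for stronger inhibition and higher numbers for weaker inhibition:

compound 1, `O=C(CSc1nc(Nc2ccccc2)c2ccccc2n1)Nc1ccccc1F`, 9350 nM
compound 2, `O=C(CSc1nc(Nc2ccccc2)c2ccccc2n1)Nc1ccccc1Cl`, 9610 nM
compound 3, `C=CC(=O)Nc1cccc(NC(=O)CSc2nc(Nc3ccccc3F)c3ccccc3n2)c1`, 6580 nM

Compound 2 differs from compound 1 only by chloro in place of fluoro on an aromatic carbon, and in this assay this gave a 1.0-fold higher number from compound 1 to compound 2 (0.01 log units; within the scatter). Compound 3 carries a different core; how the two cores of compound 1 and compound 3 differ is not broken down here. Its value in this assay stands close to those of compound 1 and compound 2, and the gaps between them are within the scatter, so no order among the three can be drawn.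

Compound 4, `C=CC(=O)Nc1cccc(NC(=O)CSc2nc(Nc3ccccc3Cl)c3ccccc3n2)c1`, has not yet been measured. It differs from compound 3 by chloro in place of fluoro on an aromatic carbon, the same change that separates compound 2 from compound 1, made at the same place. Because a 1.0-fold higher number from compound 1 to compound 2 (0.01 log units; within the scatter) was flat, compound 4 is expected to give a step of a 1.0-fold higher number from compound 3 to compound 4 (0.01 log units; within the scatter), essentially no change. Within the data shown here, the estimate for compound 4 in this assay is 6800 nM, expected to fall between 3400 nM and 13600 nM, since only one earlier example of this change is at hand.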

Compound 4, half-maximal inhibitory concentration: 10000 nM
For compound 4 the middle estimate is 1.5-fold (0.17 log units) below the measured one; the range from low to high includes it.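

Chloro in place of fluoro gave, in this assay, a 1.5-fold higher number from compound 3 to compound 4 (0.18 log units; within the scatter). Set beside the earlier example of the same change, this step does not mark the two cores as different: the same change on two cores in this assay, a 1.0-fold higher number (0.01 log units; within the scatter) from compound 1 to compound 2 and a 1.5-fold higher number (0.18 log units; within the scatter) from compound 3 to compound 4, 1.5-fold (0.17 log units) apart, within the scatter of two such steps. So in this series the change carried from one core to the other without a step that can be told from the scatter on either core, but two pairs in a single assay do not show that it would stay flat on a further core, nor do they rule out a small difference between these two cores that the scatter hides.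

The compounds shown leave open whether a group other than the two halogens at this place, such as bromo, methoxy or an amine, would give a step beyond the scatter on either core. They also leave open whether the flat result for this change would hold on cell lines other than the one used here.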